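Compound 3: one methoxy fewer than compound 2

The source may report more compounds than this note shows. Statements on the series, on what has been measured and on what is new or still open speak of the compounds shown alone.

In a functional assay on COLO 205 cells (Homo sapiens) for inhibition, read by sulforhodamine B assay, with a stated time of 48 h, tested at 50 uM (on this read-out lower numbers stand for less inhibition of growth and higher numbers for more inhibition of growth at the one concentration tested), compound 2 `COc1cc(/C=C/C(=O)/C=C/c2cc(OC)c(OC)c(OC)c2)ccc1OCc1cn(CCOc2cc(=O)oc3ccccc23)nn1` reads 86% and stands highest, while compound 1 `COc1cccc(/C=C/C(=O)/C=C/c2ccc(OCc3cn(CCOc4cc(=O)oc5ccccc45)nn3)c(OC)c2)c1` reads 69% and stands lower. Compound 3 `COc1ccc(/C=C/C(=O)/C=C/c2ccc(OCc3cn(CCOc4cc(=O)oc5ccccc45)nn3)c(OC)c2)cc1OC` carries 3,4-dimethoxyphenyl in place of 3,4,5-trimethoxyphenyl (hydrogen in place of methoxy on an aromatic carbon). Among the compounds with values here, the one measured step bearing on this is a number 17 percentage points higher from compound 1 to compound 2 (beyond the scatter) on the same phenyl group, and compound 3 falls structurally between compound 1 and compound 2. A smaller step downward is therefore expected in this assay and it may not clear the scatter. The estimated change is a number 10 percentage points lower from compound 2 to compound 3 (within the scatter) on this reasoning. For compound 3 the expected value is 76% (range 62% to 88%).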

Compound 3, percent growth inhibition at one concentration: 80%
For compound 3 the middle estimate is 4 percentage points below the measured one; measured number inside the range.
By their numbers in this assay, from the lowest: compound 1; then compounds 3 and 2 (each within the scatter of the next).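

In this assay, 3,4-dimethoxyphenyl in place of 3,4,5-trimethoxyphenyl gives a number 6 percentage points lower from compound 2 to compound 3 (within the scatter) and so shows that hydrogen is tolerated in place of this methoxy. Adding a methoxy to the 3-methoxyphenyl group gives a number 11 percentage points higher from compound 1 to compound 3 (beyond the scatter) and so, on this ring, only that single addition reads beyond the scatter. Nothing at hand gives a cause for either step. Still open, on these data alone, is whether a group other than methoxy on this aromatic carbon, such as an amine, a hydroxyl or a carboxylic acid, would hold the read-out.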